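Hydroxyphenyl Hydrazones on a Shared Core: Estimating Compound 4

The source may report more compounds than this note shows. Statements on the series, on what has been measured and on what is new or still open speak of the compounds shown alone.

Measured compounds:
compound 1, `CN(C)CCn1cnnc1-c1cc(Oc2ccc(NC(=O)N/N=C/c3cccc(O)c3)cc2F)ccn1`, 330 nM in a functional assay on HT-29 cells (Homo sapiens) for cytotoxicity, read by MTT assay, with a stated time of 72 h; on this read-out lower numbers stand for stronger inhibition and higher numbers for weaker inhibition
compound 2, `CN(C)CCn1cnnc1-c1cc(Oc2ccc(NC(=O)N/N=C/c3ccc(F)cc3Cl)cc2F)ccn1`, 510 nM
compound 3, `CN(C)CCn1cnnc1-c1cc(Oc2ccc(NC(=O)N/N=C/c3ccc(O)c(F)c3)cc2F)ccn1`, 3310 nM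

Compound 1 gives the lowest number of the three: the step of a 1.5-fold higher number from compound 1 to compound 2 (0.19 log units; within the scatter) stays within the scatter, whereas a 10-fold higher number from compound 1 to compound 3 (1.00 log units; beyond the scatter) lies beyond it. Compound 4 `COc1cc(/C=N/NC(=O)Nc2ccc(Oc3ccnc(-c4nncn4CCN(C)C)c3)c(F)c2)ccc1O` is not yet measured. Its change from compound 1 is 4-hydroxy-3-methoxyphenyl in place of 3-hydroxyphenyl on a carbon with a double bond to nitrogen. The 3-fluoro-4-hydroxyphenyl group of compound 3 is the nearest match to the entering group, so the step that bears on compound 4 is a 10-fold higher number from compound 1 to compound 3 (1.00 log units; beyond the scatter); the step of a 6.5-fold higher number from compound 2 to compound 3 (0.81 log units; beyond the scatter) points the same way. A rise of similar size is therefore expected, a 6.1-fold higher number from compound 1 to compound 4 (0.78 log units; beyond the scatter). Compound 4 is estimated at 2000 nM, with a range from 600 nM to 6000 nM.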

Compound 4, half-maximal inhibitory concentration: 120 nM
Beside the measured number, compound 4's estimate is 17-fold (1.22 log units) above it; the whole stated range lies above it.
By their numbers in this assay, from the lowest: compound 4; then compounds 1 and 2 (each within the scatter of the next); then compound 3.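

At this position, a single swap of methoxy in place of fluoro on an aromatic carbon gives a 28-fold lower number from compound 3 to compound 4 (1.44 log units; beyond the scatter) in this assay, so one small group on the aromatic ring can strongly shift the result. The 4-hydroxy-3-methoxyphenyl group, with more heavy atoms than 3-hydroxyphenyl, also gives a 2.8-fold lower number from compound 1 to compound 4 (0.44 log units; beyond the scatter) and a 4.3-fold lower number from compound 2 to compound 4 (0.63 log units; beyond the scatter), so the larger group here does not raise the number. No supporting measurement accounts for these shifts.

Still open, on these data alone, is whether an ethoxy group in place of the methoxy would keep the low number. An amine in place of the hydroxy is equally untested among the compounds shown.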